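A Bulkier Amide Group in a Series at the Limit

The compounds below may be only part of what the source reports. "The series", "measured", "known", "first", "only" and "open" are said of these compounds alone.

Compound 3 `CCNC(=O)c1ccc(-c2nnc(C3(c4ccc(Cl)cc4)CCC3)n2C)cc1` is one of three compounds tested in an assay on isolated protein for inhibition of 11-beta-hydroxysteroid dehydrogenase type 2 (Homo sapiens); a lower number here means a stronger inhibitor, a higher number a weaker inhibitor. In this assay compound 3 gives > 4000 nM, which is a limit of the assay and not a number. Compound 1 `Cn1c(-c2ccc(-c3cncnc3)cc2)nnc1C1(c2ccc(Cl)cc2)CCC1` reaches only > 4000 nM, again a limit. Compound 2 `CC(=O)Nc1ccc(-c2nnc(C3(c4ccc(Cl)cc4)CCC3)n2C)c(Cl)c1` also stops at the limit > 4000 nM. All three sit at the limit of > 4000 nM in this assay, at which 3 of the 3 values shown sit, so compound 3 stands among compounds with no measurable inhibition. Within the data shown here, the single counted step, a step that the two limits leave unreadable from compound 1 to compound 3, has no readable size; both of its ends are limits. Compound 4 `Cn1c(-c2ccc(C(=O)NC(C)(C)C)cc2)nnc1C1(c2ccc(Cl)cc2)CCC1` differs from compound 3 by tert-butyl in place of ethyl on an amide-type nitrogen. Among the measured compounds shown here, no measured step bears on this change, so the step is expected to stay within the scatter, a step that the limit leaves unreadable from compound 3 to compound 4. Compound 4 is therefore expected to give about 6000 nM, within 2000 nM to 20000 nM, most likely again only a limit.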

Compound 4, half-maximal inhibitory concentration: > 4000 nM
Compound 4 was reported as a limit; the forecaster's own chance of this, stated with the estimate: 80%; the middle value is on the limit's open side.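

The steps from compound 3 to compound 4 and from compound 1 to compound 4 cannot be read, as all three values are limits and not numbers: the limit of > 4000 nM in this assay, at which 4 of the 4 values shown sit.

The compounds shown leave open how strongly any of them inhibits the enzyme, and whether any change to the shared core would give a measurable value.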